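The compounds below may be only part of what the source reports. "The series", "measured", "known", "first", "only" and "open" are said of these compounds alone.

Working notes on the series.

Four compounds share a tertiary-alcohol amide built on an anilide bearing a trifluoromethyl group; they differ in the group on the anilide ring and in the linker and its substituted aryl partner. Compound 1 has the structure `CC(O)(CSc1cccc(S(F)(F)(F)(F)F)c1)C(=O)Nc1ccc(C#N)cc1C(F)(F)F` and compound 2 the structure `CC(O)(CSc1cccc(S(F)(F)(F)(F)F)c1)C(=O)Nc1ccc([N+](=O)[O-])cc1C(F)(F)F`. In a functional assay on DU-145 cells (Homo sapiens) for antiproliferative activity, read by propidium iodide staining, with a stated time of 96 h (on this read-out lower numbers stand for stronger inhibition and higher numbers for weaker inhibition), compound 1 gives 37400 nM, and compound 2 gives 18900 nM. The change between them is nitro in place of cyano on an aromatic carbon, and it gave a 2.0-fold lower number from compound 1 to compound 2 (0.30 log units; within the scatter).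

Compound 3 has the structure `CC(O)(COc1ccc(S(F)(F)(F)(F)F)cc1)C(=O)Nc1ccc(C#N)cc1C(F)(F)F` and in this assay gives 16000 nM. Its number stands lower than that of compound 1, beyond the scatter, while against compound 2 the two numbers lie within the scatter of each other. How the core of compound 3 differs from that of compound 1 is not broken down here.

Compound 4, with the structure `CC(O)(COc1ccc(S(F)(F)(F)(F)F)cc1)C(=O)Nc1ccc([N+](=O)[O-])cc1C(F)(F)F`, is not yet measured. It stands to compound 3 as compound 2 stands to compound 1: the change is nitro in place of cyano on an aromatic carbon, the same change on the same place. Resting on the step of a 2.0-fold lower number from compound 1 to compound 2 (0.30 log units; within the scatter) made on the core of compound 1, a step of about the same size is expected on the core of compound 3, namely a 1.7-fold lower number from compound 3 to compound 4 (0.23 log units; within the scatter), with the caution that the earlier step itself lies within the scatter. For compound 4 in this assay the estimate is 9500 nM, with a range from 4500 nM to 20000 nM.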

Compound 4, half-maximal inhibitory concentration: 15400 nM
Estimate against measurement, compound 4: 1.6-fold (0.21 log units) below, and the stated range covers the measured number.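

In this assay, within the data shown here, the same exchange of nitro for cyano on the core of compound 3 gives a 1.0-fold lower number from compound 3 to compound 4 (0.02 log units; within the scatter), so on this core it produces no step that can be told from the scatter. Set beside the step on the core of compound 1, the new step shows no sign that the outcome of this change depends on the core: the same change on two cores in this assay, a 2.0-fold lower number (0.30 log units; within the scatter) from compound 1 to compound 2 and a 1.0-fold lower number (0.02 log units; within the scatter) from compound 3 to compound 4, 1.9-fold (0.28 log units) apart, within the scatter of two such steps. Among these compounds, this shows only that the two readings are compatible: with both steps inside the scatter and only two cores at hand, it does not establish that the change has any real effect in either setting, nor that the agreement would hold on a further core.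

The compounds shown leave open whether any other group at this place on the anilide ring, such as a carboxylic acid, a primary amide or a chlorine atom, would move the number beyond the scatter, since nitrile and nitro are the only two present here. They also leave open what the linker does on its own, as the sulfur and oxygen linkers appear only with different aryl partners, and an amine linker or a longer chain does not figure among them.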